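The source may hold more compounds than are shown below. What is called first, only, known or untested is meant among the compounds shown, and "the series" means these compounds.

In a functional assay (aorta) with Rattus norvegicus as the target (a higher number here means that more compound is needed for the effect, a lower number that less compound is needed), compound 2 `N#Cc1ccc2c(c1)C(N1CCCCC1=O)=CC(CF)(CF)O2` gives 162 nM, compound 3 `O=C1CCCCN1C1=CC(CF)(CF)Oc2ccc([N+](=O)[O-])cc21` gives 17.4 nM and compound 1 `O=C1CCCN1C1=CC(CF)(CF)Oc2ccc(C(F)(F)C(F)(F)F)cc21` gives 1.51 nM. Compound 3 therefore holds the second highest of the three numbers. The next structure, compound 4 `O=C1CCCCN1C1=CC(CF)(CF)Oc2ccc(C(F)(F)C(F)(F)F)cc21`, has 1,1,2,2,2-pentafluoroethyl in place of nitro on an aromatic carbon. One measured step changes the group on this same aromatic carbon: a 9.3-fold lower number from compound 2 to compound 3 (0.97 log units; beyond the scatter), with nitro in place of cyano. It shows that the number can move beyond the scatter with a change at this place, but it does not involve the entering group. Compound 1 does carry 1,1,2,2,2-pentafluoroethyl, yet it also differs from compound 4 elsewhere in the structure, so compound 1 at 1.51 nM is only an indirect guide. A moderate step towards a lower number is thus expected in this assay. The expected change is a 3.5-fold lower number from compound 3 to compound 4 (0.54 log units; beyond the scatter). Compound 4 is estimated at 5 nM, with an expected range of 1.3 nM to 20 nM.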

Compound 4, half-maximal effective concentration: 5.62 nM
Compound 4: the middle estimate sits 1.1-fold (0.05 log units) below what was measured; low and high end bracket the measured number.
By their numbers in this assay, from the lowest: compound 1; then compound 4; then compound 3; then compound 2.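

In this assay, with 2-oxopiperidin-1-yl held constant, 1,1,2,2,2-pentafluoroethyl on this aromatic carbon gives a 3.1-fold lower number from compound 3 to compound 4 (0.49 log units; beyond the scatter) against nitro and a 29-fold lower number from compound 2 to compound 4 (1.46 log units; beyond the scatter) against cyano, so the entering group now has a direct comparison at this position and gives the lowest number of the three groups. The change on the double-bonded ring carbon can also be read on its own: 2-oxopiperidin-1-yl in place of 2-oxopyrrolidin-1-yl gives a 3.7-fold higher number from compound 1 to compound 4 (0.57 log units; beyond the scatter), so the low number of compound 1 does not come from 1,1,2,2,2-pentafluoroethyl alone. No evidence is available here to explain either change.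

The compounds shown leave open how an amine, a carboxylic acid or a longer fluorinated chain would stand on this aromatic carbon. They also leave open whether 2-oxopyrrolidin-1-yl would give a step of similar size alongside nitro or cyano.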